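This account rests on a few compounds, and the source may have more. Where it says the series, first, only, none or still open, it means among the compounds named here.

Measured compounds:
compound 1 `COc1cc(OC)c(/C=C/C(=O)c2ccccc2F)c(OC)c1` — in a functional assay on HeLa cells (Homo sapiens) for cytotoxicity, read by MTT assay, with a stated time of 72 h (on this read-out higher numbers stand for weaker inhibition and lower numbers for stronger inhibition), compound 1 gives 50.6 nM
compound 2 `COc1ccc(/C=C/C(=O)c2ccccc2F)c(OC)c1` — in this assay compound 2 gives 175 nM
compound 3 `COc1cc(OC)c(OC)cc1/C=C/C(=O)c1ccccc1F` — in this assay compound 3 gives 293 nM

Compound 3 stands at the top of these three numbers as written, but its separation from compound 2 is within the scatter and cannot be read as a ranking; only compound 1 is separated from it beyond the scatter. Compound 4 `COc1ccc(OC)c(/C=C/C(=O)c2ccccc2F)c1` differs from compound 3 by one change: hydrogen in place of methoxy on an aromatic carbon. Among the measured compounds shown here, two measured steps concern the same kind of group. Removing a methoxy group gave a 3.5-fold higher number from compound 1 to compound 2 (0.54 log units; beyond the scatter), and adding a methoxy group gave a 1.7-fold higher number from compound 2 to compound 3 (0.22 log units; within the scatter). Both a loss and a gain of methoxy thus moved the number upward, and the second of these steps stayed within the scatter, so no single direction for a methoxy removal can be read from these compounds. For compound 4 the step is therefore expected to be small, estimated as a 1.2-fold higher number from compound 3 to compound 4 (0.08 log units; within the scatter), with either direction possible. Compound 4 is expected to give about 350 nM in this assay, within a range from 120 nM to 1000 nM.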

Compound 4, half-maximal inhibitory concentration: 96.1 nM
The estimate for compound 4 lay 3.6-fold (0.56 log units) above the measured number, outside the stated range (below it).
By their numbers in this assay, from the lowest: compounds 1, 4, 2 and 3 (each within the scatter of the next, the first and the last beyond it).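

In this assay, exchanging hydrogen for the methoxy group that stands para to a large group gave a 3.0-fold lower number from compound 3 to compound 4 (0.48 log units; beyond the scatter), so at this place the loss of a methoxy group goes with a lower number, beyond the scatter. The earlier compounds had shown a methoxy loss only with a higher number, and the same exchange now runs in opposite directions, so its outcome on one core cannot be carried over to the other: the same change on two cores in this assay, a 3.5-fold higher number (0.54 log units; beyond the scatter) from compound 1 to compound 2 and a 3.0-fold lower number (0.48 log units; beyond the scatter) from compound 3 to compound 4, 11-fold (1.02 log units) apart, beyond the scatter of two such steps Among these compounds, then, the methoxy group removed from compound 3 goes with weaker inhibition, whereas the one removed from compound 1 goes with stronger inhibition, and this holds only for these two pairs.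

The compounds shown leave open whether a hydroxyl group, an ethoxy group or an amine at this place would give a number closer to that of compound 3 or that of compound 4. They also leave open whether the opposite directions of the two steps would persist on cores carrying chlorine in place of the fluorine.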